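Shortening the sulfonamide chain: compound 3 to compound 4

This account rests on a few compounds, and the source may have more. Where it says the series, first, only, none or still open, it means among the compounds named here.

Measured compounds:
compound 1: `CC[C@@H]1C(=O)N(C)c2cnc(-n3ccc4cc(F)ccc43)nc2N1C1CCCC1`, 969 nM
compound 2: `CC[C@@H]1C(=O)N(C)c2cnc(Nc3ccc(S(=O)(=O)NC4CCCC4)cc3)nc2N1C1CCCC1`, 23.9 nM
compound 3: `CCCCNS(=O)(=O)c1ccc(Nc2ncc3c(n2)N(c2ccn(C)n2)C(CC)C(=O)N3C)cc1`, 191 nM

All three were run in an assay for inhibition of serine/threonine-protein kinase PLK2 (Homo sapiens), read by FRET and Z'-LYTE, with a stated time of 1 h; a higher number here means a weaker inhibitor, a lower number a stronger inhibitor. Among the three numbers, compound 3 stands second highest. Compound 1 sits above it, beyond the scatter, and compound 2 sits below it, also beyond the scatter. Compounds 2 and 3 both carry a sulfonamide aniline on the shared core, but they differ in more than one place, so their two values are noted side by side without reading a single cause into the gap.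

Compound 4, `CCCNS(=O)(=O)c1ccc(Nc2ncc3c(n2)N(c2ccn(C)n2)C(CC)C(=O)N3C)cc1`, is the next compound to be measured. It differs from compound 3 in one place: hydrogen in place of methyl on a saturated chain carbon, three bonds along the chain from a sulfonamide nitrogen. The change removes one carbon from the alkyl chain on the sulfonamide nitrogen and nothing else in the molecule moves.

Within the data shown here, no measured pair in this set isolates a change of this kind, so there is no direct precedent to lean on. For compound 4 the expectation is a step within the usual scatter, with no clear direction: a 1.0-fold higher number from compound 3 to compound 4 (0.02 log units; within the scatter). The estimate for compound 4 is 200 nM, with a range from 80 nM to 500 nM.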

Compound 4, half-maximal inhibitory concentration: 190 nM
Beside the measured number, compound 4's estimate is 1.1-fold (0.02 log units) above it; the measured number falls inside the stated range.
By their numbers in this assay, from the lowest: compound 2; then compounds 4 and 3 (each within the scatter of the next); then compound 1.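

In this assay, hydrogen in place of methyl on a saturated chain carbon, three bonds along the chain from a sulfonamide nitrogen, gives a 1.0-fold lower number from compound 3 to compound 4 (0.00 log units; within the scatter). Among these compounds, this is the first step that isolates a single place, and it shows that, with the rest of compound 3 held fixed, going from butyl to propyl on the sulfonamide nitrogen leaves the reading within the scatter. The end carbon of the butyl chain therefore makes no measurable difference to the number in this one pair, although a single step cannot show how far that holds along the chain, and no measurement here bears on why the step is so small.

The compounds shown leave open whether a still shorter chain such as ethyl or methyl, a longer chain, or a chain ending in an amine or a carboxylic acid would stay within the scatter of compound 4. They also leave open what sets compound 2 at 23.9 nM, since compound 2 differs from compound 4 in more than one place and that gap cannot be assigned to the sulfonamide substituent alone.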